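Butylamino in place of isopropylsulfanyl: a series at its limit

The source may report more compounds than this note shows. Statements on the series, on what has been measured and on what is new or still open speak of the compounds shown alone.

Measured in an ADME assay on BCBL1 cells (Homo sapiens) for cytotoxicity, with a stated time of 7 days; on this read-out lower numbers stand for higher toxicity in this test and higher numbers for lower toxicity in this test; all three values are limits:
- compound 1 `CCCNc1nc(N)nc2c1ncn2/C=C1/CC1(CO)CO`: > 20000 nM
- compound 2 `CSc1nc(N)nc2c1ncn2/C=C1/CC1(CO)CO`: > 20000 nM
- compound 3 `CC(C)Sc1nc(N)nc2c1ncn2/C=C1/CC1(CO)CO`: > 20000 nM

Compound 3 has only a limit, > 20000 nM, so it cannot be ranked against the other two compounds. The next compound, compound 4 `CCCCNc1nc(N)nc2c1ncn2/C=C1/CC1(CO)CO`, carries butylamino in place of isopropylsulfanyl on an aromatic carbon.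

The closest measured change is a step that the two limits leave unreadable from compound 1 to compound 3. The two others are a step that the two limits leave unreadable from compound 1 to compound 2 and a step that the two limits leave unreadable from compound 2 to compound 3. None of them gives a size. Propylamino is the measured group nearest to butylamino, and compound 1 carries it, again with a limit, > 20000 nM. The whole picture is the limit of > 20000 nM in this assay, at which 3 of the 3 values shown sit. For the measured compounds named here, on that basis, no step of readable size is expected in this assay, and no direction can be assigned. Another limit is the most likely report for the next measurement. For compound 4 the estimated value is 25000 nM, with an expected range of 10000 nM to 40000 nM. The expected step is a step that the limit leaves unreadable from compound 3 to compound 4.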

Compound 4, half-maximal cytotoxic concentration: > 20000 nM
Compound 4: only a limit was reported; the forecaster's own chance of this, stated with the estimate: 80%; the middle value does not contradict the limit.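

In this assay compound 4 gives > 20000 nM as a limit. No step from compound 1, compound 2 or compound 3 to compound 4 can be read: the limit of > 20000 nM in this assay, at which 4 of the 4 values shown sit.

The compounds shown leave open whether these four differ in cytotoxicity at all, and by how much.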